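The source may report more compounds than this note shows. Statements on the series, on what has been measured and on what is new or still open speak of the compounds shown alone.

Measured so far in a functional assay on CCRF-CEM cells (Homo sapiens) for inhibition, read by sulforhodamine B assay, with a stated time of 48 h; on this read-out lower numbers stand for stronger inhibition of growth and higher numbers for weaker inhibition of growth:
compound 1 `CN1CCN(CCCOc2cccc3nc(Nc4ccc(Cl)c(F)c4)ccc23)CC1`: "not determined" (no result reported)
compound 2 `CC(C)c1ccc(Nc2ccc3c(OCCCN4CCN(C)CC4)cccc3n2)cc1`: 3740 nM
compound 3 `CN1CCN(CCCOc2cccc3nc(Nc4ccc(F)c(F)c4)ccc23)CC1`: 2420 nM

Among the measured compounds shown here, compound 3, at 2420 nM, has only one numerical neighbour: compound 2, at 3740 nM, lies within the scatter of it. Compound 1 provides no number for comparison.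

Compound 4 `CN1CCN(CCCOc2cccc3nc(Nc4cccc(Cl)c4)ccc23)CC1` is the next entry, with 3-chlorophenyl in place of 3,4-difluorophenyl on a nitrogen on an aromatic ring.

For the measured compounds named here, one measured step bears on this change, as it falls at the same place: a 1.5-fold lower number from compound 2 to compound 3 (0.19 log units; within the scatter). It stays within the scatter, so no shift beyond the scatter is expected in either direction in this assay. The expected change is a 1.1-fold higher number from compound 3 to compound 4 (0.03 log units; within the scatter).

Compound 4 is estimated at 2600 nM, with an expected range of 1200 nM to 5500 nM.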

Compound 4, concentration for 50% growth inhibition: 1680 nM
Estimate against measurement, compound 4: 1.5-fold (0.19 log units) above; low and high end bracket the measured number.
By their numbers in this assay, from the lowest: compounds 4, 3 and 2 (each within the scatter of the next, the first and the last beyond it).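

In this assay the change from 3,4-difluorophenyl to 3-chlorophenyl on the nitrogen stays small (a 1.4-fold lower number from compound 3 to compound 4 (0.16 log units; within the scatter)). Among the compounds shown here, the comparison of 3-chlorophenyl with 4-isopropylphenyl gives the first step at this position beyond the scatter, though a modest one (a 2.2-fold lower number from compound 2 to compound 4 (0.35 log units; beyond the scatter)). No measurement shown accounts for this difference.

Still open, from the compounds shown here alone, is how an unsubstituted phenyl, a pyridyl or a cyclohexyl on this nitrogen would compare. Also open, going by these compounds, is whether an amine or a carboxylic acid on the phenyl ring would be tolerated.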